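Swapping Fluoro for Methoxy in a Cell-Toxicity Series

This account rests on a few compounds, and the source may have more. Where it says the series, first, only, none or still open, it means among the compounds named here.

Of the compounds shown here, two have been tested so far in a functional assay on LOX IMVI cells (Homo sapiens) for inhibition, read by sulforhodamine B assay, with a stated time of 48 h; on this read-out lower numbers stand for higher toxicity in this test and higher numbers for lower toxicity in this test. Going by the values given here, compound 1 `Nc1cc(N)c2nc(-c3ccccc3)c(Sc3ccc(F)cc3)nc2c1` kills cells only at high concentration: in this assay compound 1 gives 74100 nM, the single plain number in this set. Compound 2 `COc1ccc(CNc2nc3cc(N)cc(N)c3nc2-c2ccccc2)cc1OC` carries a dimethoxybenzylamine in place of the sulfur-linked ring. For compound 2 the reading in this assay is < 100000 nM, which is a limit of the assay rather than a number. Compound 1 therefore stands alone as the one measured point, while the other value sits at the limit of < 100000 nM in this assay, at which 1 of the 2 values shown sits.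

Compound 3 `COc1ccc(Sc2nc3cc(N)cc(N)c3nc2-c2ccccc2)cc1` differs from compound 1 in one place: methoxy in place of fluoro on an aromatic carbon. Among the compounds with values here, no step between two measured compounds is available to calibrate a change of this kind, so the expectation rests on the small size of the swap alone. Such a change is expected to shift the reading little, if at all, beyond the usual scatter. Compound 3 is therefore estimated to give 60000 nM in this assay, with a range from 25000 nM to 150000 nM. The step expected a 1.2-fold lower number from compound 1 to compound 3 (0.09 log units; within the scatter) is small.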

Compound 3, concentration lethal to 50% of the cells: < 100000 nM
Compound 3 was reported as a limit (the forecaster's own chance of this, stated with the estimate: 25%); the middle value lies beyond the limit too.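

Compound 3 is reported only as a limit and not as a number, so no step from compound 1 to compound 3 can be read in this assay: the limit of < 100000 nM in this assay, at which 2 of the 3 values shown sit.

The compounds shown leave open whether methoxy in place of fluoro on an aromatic carbon changes the reading at all, and in which direction.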